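The compounds below may be only part of what the source reports. "The series", "measured", "known", "first", "only" and "open" are said of these compounds alone.

In an assay on CHO-K1 cells for displacement of a labelled ligand from prostaglandin E2 receptor EP1 subtype (Homo sapiens) (on this read-out higher numbers stand for weaker inhibition and lower numbers for stronger inhibition), compound 1 `Cc1cc(C(=O)NCc2cccnc2)nn1Cc1cc(Cl)ccc1OCc1ccccc1` gives 50.1 nM, the second highest of the three numbers measured. Compound 3 `Cc1cc(NC(=O)C2CCCC2)nn1Cc1cc(Cl)ccc1OCC(C)C` gives 25.1 nM, within the scatter of compound 1, while compound 2 `Cc1cc(C(=O)NN2CCOCC2)nn1Cc1cc(Cl)ccc1OCC(C)C` gives 251 nM, a higher number beyond the scatter. Compound 4 `Cc1cc(NC(=O)OC(C)(C)C)nn1Cc1cc(Cl)ccc1OCc1ccccc1` is not yet measured; it differs from compound 1 in one place: (tert-butoxycarbonyl)amino in place of ((pyridin-3-yl)methyl)carbamoyl on an aromatic carbon. Among the compounds with values here, the one measured step that bears on this is a 10-fold lower number from compound 2 to compound 3 (1.00 log units; beyond the scatter), where a carbamoyl group was likewise exchanged for an amino group carrying a carbonyl. That step involved different groups. Its size carries over only loosely. A lower number is therefore expected for compound 4, a 2.5-fold lower number from compound 1 to compound 4 (0.40 log units; beyond the scatter). The estimate for compound 4 in this assay is 20 nM, ranging from 6 nM to 80 nM.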

Compound 4, half-maximal inhibitory concentration: 25.1 nM
The estimate for compound 4 lay 1.3-fold (0.10 log units) below the measured number; the measured number falls inside the stated range.
By their numbers in this assay, from the lowest: compounds 3, 4 and 1 (each within the scatter of the next); then compound 2.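

At this aromatic carbon of the shared core, (tert-butoxycarbonyl)amino takes the place of ((pyridin-3-yl)methyl)carbamoyl with a 2.0-fold lower number from compound 1 to compound 4 (0.30 log units; within the scatter) in this assay, so the six-membered aromatic ring of the group that leaves is not required for a number of this size. The exchange of a carbamoyl for a carbonyl-bearing amino group therefore has no fixed effect, since a 10-fold lower number from compound 2 to compound 3 (1.00 log units; beyond the scatter) is beyond the scatter. Nothing measured here explains why these numbers differ or agree.

On these data alone, a plain amine or a carboxylic acid on this aromatic carbon remains open. So does whether a shorter carbamate, such as the methyl one, would give a number close to that of compound 4.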